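Swapping the aryl group on a triazole-linked indole ester

This account rests on a few compounds, and the source may have more. Where it says the series, first, only, none or still open, it means among the compounds named here.

Of the compounds shown here, two have been tested in a functional assay on HeLa cells (Homo sapiens) for cytotoxicity, read by MTT assay, with a stated time of 48 h; a higher number here means a weaker inhibitor, a lower number a stronger inhibitor. Compound 1, `Cc1cccc(-n2cc(COC(=O)c3cc4ccccc4[nH]3)nn2)c1C`, gives 30300 nM in this assay. Compound 2, `O=C(OCc1cn(-c2ccccc2Br)nn1)c1cc2ccccc2n1Cc1cn(-c2ccccc2Br)nn1`, which carries two bromophenyl-bearing triazole arms, gives 35900 nM in this assay. The two numbers sit close together, and their gap lies within the usual scatter, so neither compound can be called the more potent.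

Compound 3, `O=C(OCc1cn(-c2ccccc2Br)nn1)c1cc2ccccc2[nH]1`, is the next compound of interest and has not yet been measured. It differs from compound 1 in one place: 2-bromophenyl in place of 2,3-dimethylphenyl on an aromatic nitrogen. Within the data shown here, no measured pair shows what this change does on its own. Because compound 2, which already carries the 2-bromophenyl group, gives 35900 nM, the change is expected to move the number little, if at all. The step from compound 1 to compound 3 is therefore estimated at a 1.2-fold higher number from compound 1 to compound 3 (0.06 log units; within the scatter). Compound 3 is expected to give about 35000 nM, within a range of 12000 nM to 100000 nM.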

Compound 3, half-maximal inhibitory concentration: 17300 nM
For compound 3 the middle estimate is 2.0-fold (0.31 log units) above the measured one; the range from low to high includes it.
By their numbers in this assay, from the lowest: compounds 3, 1 and 2 (each within the scatter of the next, the first and the last beyond it).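

Among these compounds, this is the first pair of compounds that isolates the aryl group on the aromatic nitrogen of the five-membered ring with 3 nitrogen. Putting 2-bromophenyl in place of 2,3-dimethylphenyl gives a 1.8-fold lower number from compound 1 to compound 3 (0.24 log units; within the scatter) in this assay and this step stays within the scatter, so the two groups cannot be told apart at this position, although one carries a bromine and the other two methyl groups. No supporting measurement bears on this result.

From the compounds shown here alone, only these two aryl groups can be compared directly at this position, so it remains open whether a plain phenyl, or an aryl ring carrying an amine or a carboxylic acid, would give a similar number. Also open, going by these compounds, is what an amide in place of the ester would do.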